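A few compounds are considered here, and "the series" means these few. Any claim that something is new, unique, unknown or untested is made for them only; others in the source may bear on it.

Compound 3 `Cc1cc(C)cc(S(=O)(=O)c2c(C(=O)NC(C)C(=O)NCc3ccncc3)[nH]c3ccc(Cl)cc23)c1` gives 19500 nM in an ADME assay on MT4 cells (Homo sapiens) for cytotoxicity, read by MTT assay (a higher number here means that more compound is tolerated, a lower number that less compound is tolerated), the lowest of the two numbers measured there. Its nearest neighbour is compound 2 `Cc1cc(C)cc(S(=O)(=O)c2c(C(=O)NCC(=O)NC(C)c3ccccc3)[nH]c3ccc(Cl)cc23)c1`, which gives 29400 nM in this assay; the two sit within the scatter of each other, and the step of a 1.5-fold lower number from compound 2 to compound 3 (0.18 log units; within the scatter) carries no weight of its own. Compound 1 `Cc1cc(C)cc(S(=O)(=O)c2c(C(=O)NC(c3ccc(Cl)cc3)C3CC3)[nH]c3ccc(Cl)cc23)c1` reached only the limit > 47300 nM in this assay, as the evidence the limit of > 47300 nM in this assay, at which 1 of the 3 values shown sits, records, so its value is a limit and not a number. From that limit the steps were an at least 1.6-fold lower number from compound 1 to compound 2 (0.20 log units; that floor lies within the scatter) and an at least 2.4-fold lower number from compound 1 to compound 3 (0.38 log units; beyond the scatter).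

Compound 4 `Cc1cc(C)cc(S(=O)(=O)c2c(C(=O)NC(C)c3cc(F)cc(F)c3)[nH]c3ccc(Cl)cc23)c1` differs from compound 3 in one place: 3,5-difluorophenyl in place of ((pyridin-4-yl)methyl)carbamoyl on a saturated chain carbon bound to an amide-type nitrogen and a saturated chain carbon. This change runs in the opposite sense to the step from compound 1 to compound 3, which introduced the ((pyridin-4-yl)methyl)carbamoyl piece; compound 4 returns to a single amide bearing an aromatic ring of carbon only, as in compound 1. Compound 4 is therefore expected to give a somewhat higher number, estimated at 35000 nM in this assay, between 15000 nM and 60000 nM, a step of a 1.8-fold higher number from compound 3 to compound 4 (0.25 log units; within the scatter), with a fair chance that only a limit is reported.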

Compound 4, half-maximal cytotoxic concentration: > 49700 nM
Compound 4: no number, only a limit; the forecaster's own chance of this, stated with the estimate: 35%; at least 1.4-fold (0.15 log units) between middle value and limit.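

In this assay compound 4 gives a limit and not a number: the limit of > 49700 nM in this assay, at which 1 of the 4 values shown sits. Within the data shown here, on this saturated chain carbon, 3,5-difluorophenyl in place of ((pyridin-4-yl)methyl)carbamoyl brings an at least 2.5-fold higher number from compound 3 to compound 4 (0.40 log units; beyond the scatter), so a change confined to this one place is enough to move the number beyond the scatter, which the earlier compounds showed only for exchanges of the whole group on the amide-type nitrogen. The second step, an at least 1.6-fold higher number from compound 2 to compound 4 (0.22 log units; that floor lies within the scatter), has a floor within the scatter and does not separate that pair, and the step that joins the two limits cannot be read.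

Which part of the exchange carries the step remains open, the carbamoyl link or the ring it holds. From the compounds shown here alone, how a carboxylic acid or a longer chain ending in an amine would read on this carbon also remains open.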